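The source may hold more compounds than are shown below. What is called first, only, known or untested is meant among the compounds shown, and "the series" means these compounds.

Two compounds have been measured so far:

Compound 1, `CC(C)N(Cc1cccc(OCCCCCC(=O)O)c1)C(=O)c1ccc(-c2cccc(N(C)C)c2)cc1`, gives > 26000 nM in an ADME assay on BJ cells (Homo sapiens) for cytotoxicity, read by CellTiter-Glo and resazurin assay, with a stated time of 72 h; on this read-out lower numbers stand for an effect already at smaller amounts and higher numbers for an effect only at larger amounts of compound.
Compound 2, `CC(=O)Nc1cccc(-c2ccc(C(=O)N(Cc3cccc(OCCCCCC(=O)O)c3)C(C)C)cc2)c1`, gives > 26000 nM in this assay.

Both numbers are limits of the assay rather than measured values. For compound 1 the result in this assay is a limit, > 26000 nM. For compound 2 the result in this assay is likewise a limit, > 26000 nM. This is where compound 2 stands: at the limit of > 26000 nM in this assay, at which 2 of the 2 values shown sit, with no figure of its own. Among the measured compounds shown here, the one measured step, a step that the two limits leave unreadable from compound 1 to compound 2, therefore cannot be read, and no other step exists.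

Compound 3, `CC(C)N(Cc1cccc(OCCCCCC(=O)O)c1)C(=O)c1ccc(-c2cccc(F)c2)cc1`, has not yet been measured. It differs from compound 2 by fluoro in place of acetamido on an aromatic carbon. For the measured compounds named here, no measured step bears on this change: the only step, from compound 1 to compound 2, shows nothing readable, so the series offers no basis for expecting a step beyond the scatter in either direction in this assay. Compound 3 is therefore expected to sit near the same limit, with an estimated 40000 nM in this assay, between 15000 nM and 150000 nM. This amounts to an expected step that the limit leaves unreadable from compound 2 to compound 3 from compound 2 to compound 3, which most likely will again appear only as a limit.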

Compound 3, half-maximal effective concentration: > 26000 nM
Compound 3 ended at the assay's limit; the forecaster's own chance of this, stated with the estimate: 80%; the middle value does not contradict the limit.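

Compound 3 joins compound 1 and compound 2 at a limit of the assay, so neither the change from compound 2 to compound 3 nor that from compound 1 to compound 3 can be read: the limit of > 26000 nM in this assay, at which 3 of the 3 values shown sit.

The compounds shown leave open whether dimethylamino, acetamido and fluoro differ at all in this assay.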